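The source may hold more compounds than are shown below. What is called first, only, known or untested is meant among the compounds shown, and "the series" means these compounds.

In a functional assay, with a stated time of 150 min, tested at 20 ug/mL (on this read-out lower numbers stand for a weaker effect and higher numbers for a stronger effect at the one concentration tested), compound 1 `COC(=O)c1c(Nc2ccccc2)sc(C(=O)c2ccc(OC)cc2)c1C` gives 32.4%, while compound 3 `COC(=O)c1c(Nc2ccc(OC)cc2)sc(C(=O)c2ccc(OC)cc2)c1C` gives 12%, the lowest of the two numbers shown; compound 2 `COC(=O)c1c(Nc2ccc(C)cc2)sc(C(=O)c2ccc(OC)cc2)c1C` is reported as "not active" (no number reported) without a number. Within the data shown here, the one measured step that bears on this comparison is a number 20.4 percentage points lower from compound 1 to compound 3 (beyond the scatter). Compound 4 `COC(=O)c1c(Nc2ccc(F)cc2)sc(C(=O)c2ccc(OC)cc2)c1C` differs from compound 3 in one place: fluoro in place of methoxy on an aromatic carbon. Among the measured compounds shown here, no measured step swaps one such group for another, so the expectation rests on the two other compounds: compound 1, with hydrogen instead, stands higher, and compound 2, with methyl, gives no number. Compound 4 is therefore expected to stay close to compound 3, with a number 3 percentage points higher from compound 3 to compound 4 (within the scatter) not beyond the scatter. Compound 4 is estimated at 15%, between 0% and 35% in this assay.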

Compound 4, a percentage reported as activity, at one concentration (the size of the read-out at that concentration, not a potency): 18.2%
Beside the measured number, compound 4's estimate is 3.2 percentage points below it, within the range that was stated.
By their numbers in this assay, from the lowest: compounds 3 and 4 (each within the scatter of the next); then compound 1.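

In this assay the swap of methoxy for fluoro on this aromatic carbon gives a number 6.2 percentage points higher from compound 3 to compound 4 (within the scatter) so the two groups cannot be told apart here. Fluoro in place of hydrogen gives a number 14.2 percentage points lower from compound 1 to compound 4 (beyond the scatter) and methoxy in place of hydrogen gives a number 20.4 percentage points lower from compound 1 to compound 3 (beyond the scatter) so both groups with a number now stand below the hydrogen of compound 1. No measurement shown explains these differences.

Open, on these data alone, is how an amine or a carboxylic acid at this place would read. Also open, as far as these compounds go, is whether any group here can match compound 1 at 32.4% in this assay.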